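Cyclobutyl in Place of Tert-Butyl on a Sulfur

The compounds below may be only part of what the source reports. "The series", "measured", "known", "first", "only" and "open" are said of these compounds alone.

Compound 1 `Cc1nc(S(C)(=O)=O)ccc1Oc1ncnc(OC2CCN(C(=O)OC(C)C)CC2)c1F`: 142 nM
Compound 2 `Cc1nc(S(C)(=O)=O)ccc1Oc1ncnc(OC2CCN(C(=O)SC(C)C)CC2)c1F`: 41.3 nM
Compound 3 `Cc1nc(S(C)(=O)=O)ccc1Oc1ncnc(OC2CCN(C(=O)SC(C)(C)C)CC2)c1F`: 30.7 nM

In a functional assay on isolated protein for inhibition of Glucose-dependent insulinotropic receptor (Rattus norvegicus), read by HTRF and cAMP accumulation (a higher number here means that more compound is needed for the effect, a lower number that less compound is needed), compound 3 has the lowest number of the three. The step of a 4.6-fold lower number from compound 1 to compound 3 (0.67 log units; beyond the scatter) lies beyond the scatter, whereas a 1.3-fold lower number from compound 2 to compound 3 (0.13 log units; within the scatter) does not, so compound 2 and compound 3 cannot be ranked against each other.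

Compound 4 `Cc1nc(S(C)(=O)=O)ccc1Oc1ncnc(OC2CCN(C(=O)SC3CCC3)CC2)c1F` differs from compound 3 by cyclobutyl in place of tert-butyl on a sulfur. Among the compounds with values here, the only measured step that changes the carbon group on that sulfur is a 1.3-fold lower number from compound 2 to compound 3 (0.13 log units; within the scatter), which stayed within the scatter; the larger steps of a 3.4-fold lower number from compound 1 to compound 2 (0.54 log units; beyond the scatter) and a 4.6-fold lower number from compound 1 to compound 3 (0.67 log units; beyond the scatter) changed oxygen to sulfur instead and do not bear on this change. For compound 4 a step of a 1.2-fold higher number from compound 3 to compound 4 (0.07 log units; within the scatter) is therefore expected, nothing beyond the scatter. Compound 4 is estimated at 36 nM, between 15 nM and 85 nM.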

Compound 4, half-maximal effective concentration: 77.4 nM
Compound 4: the middle estimate sits 2.2-fold (0.33 log units) below what was measured; measured number inside the range.
By their numbers in this assay, from the lowest: compounds 3, 2, 4 and 1 (each within the scatter of the next, the first and the last beyond it).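

Compound 4 shows that the carbon group on this sulfur can matter in this assay: replacing tert-butyl with cyclobutyl gives a 2.5-fold higher number from compound 3 to compound 4 (0.40 log units; beyond the scatter) even though the earlier change on the sulfur stayed within the scatter. The steps of a 1.9-fold higher number from compound 2 to compound 4 (0.27 log units; within the scatter) and a 1.8-fold lower number from compound 1 to compound 4 (0.26 log units; within the scatter) both stay within the scatter, so neither pair can be ranked. Thus, sulfur on the carbonyl carbon does not always give a step from compound 1 beyond the scatter, and compound 4 goes against compound 2 and compound 3 here.

No evidence explains the difference between cyclobutyl and tert-butyl. As far as these compounds go, whether cyclopropyl, cyclohexyl or an amine on the carbonyl carbon would track compound 3 or compound 4 remains open.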